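A few compounds are considered here, and "the series" means these few. Any claim that something is new, unique, unknown or untested is made for them only; others in the source may bear on it.

Measured compounds in the series:

compound 1, `[N-]=[N+]=NCC(O)Cn1c(=O)n(C2OC(CO)[C@@H](O)[C@H]2O)c2nc(N)nc(O)c21` — 39 uM
compound 2, `C=CCn1c(=O)n(C2CN(CCCC)CC(CO)O2)c2nc(N)nc(O)c21` — 5 uM
compound 3, `C=CCn1c(=O)n(CCCCCCCC)c2nc(N)nc(O)c21` — 37 uM

All three values come from a functional assay (B cells) with Mus musculus as the target; a higher number here means that more compound is needed for the effect, a lower number that less compound is needed. Compound 1 carries the highest number of the three. Against compound 3 the gap lies within the scatter, so no order between the two can be drawn; against compound 2 the gap is beyond the scatter, and compound 2 stands at the lower number. No pair of these compounds differs in one place only, so no single step is available to lean on.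

Compound 4, `COc1ccc(Cn2c(=O)n(C3OC(CO)[C@@H](O)[C@H]3O)c3nc(N)nc(O)c32)cc1`, is not yet measured in this assay. It keeps the core and the sugar of compound 1 and differs in one place: 4-methoxyphenyl in place of 2-azido-1-hydroxyethyl on a saturated chain carbon bound to an aromatic nitrogen. Within the data shown here, nothing among the measured compounds isolates this change; the three measured compounds vary at several positions at once. The step is therefore expected to be small, towards a lower number if anything, and may well stay within the scatter. Compound 4 is estimated at 20 uM, with a range from 5 uM to 80 uM, which means an expected step of a 2.0-fold lower number from compound 1 to compound 4 (0.29 log units; within the scatter).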

Compound 4, concentration for half-maximal effect: 135 uM
Compound 4: middle estimate off by 6.8-fold (0.83 log units), on the low side; the whole stated range lies below it.
By their numbers in this assay, from the lowest: compound 2; then compounds 3 and 1 (each within the scatter of the next); then compound 4.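

In this assay, among these compounds, the one-place change from 3-azido-2-hydroxypropyl to 4-methoxybenzyl gives a 3.5-fold higher number from compound 1 to compound 4 (0.54 log units; beyond the scatter), so the number responds to the group at this position, which the earlier compounds, varying at several positions at once, could not show. On this single pair, the entering group, with its six-membered aromatic ring of carbon only and no hydrogen-bond donor, goes with the higher number. No measurement at hand bears on the reason for this step.

This one pair cannot separate the loss of the azido group, the loss of the hydroxyl and the gain of the aromatic ring. Going by these compounds, it also remains open where an unsubstituted benzyl or a 3-aminopropyl chain at this position would fall relative to compound 1 and compound 4.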